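Thiophenyl for benzofuranyl on a nucleoside core

This account rests on a few compounds, and the source may have more. Where it says the series, first, only, none or still open, it means among the compounds named here.

Measured compounds:
compound 1 `Cc1ncnc2c1c(-c1cc3ccccc3o1)cn2[C@@H]1O[C@H](CO)[C@@H](O)[C@H]1O`, > 20000 nM
compound 2 `Cc1nc(N)c2c(-c3cc4ccccc4o3)cn([C@@H]3O[C@H](CO)[C@@H](O)[C@H]3O)c2n1`, > 20000 nM
compound 3 `Cc1ncnc2c1c(-c1ccsc1)cn2[C@@H]1O[C@H](CO)[C@@H](O)[C@H]1O`, 350 nM

In a functional assay on HL-60 cells (Homo sapiens) for antiproliferative activity, read by XTT assay, with a stated time of 72 h (a lower number here means a stronger inhibitor, a higher number a weaker inhibitor), compound 1 gives only a limit, > 20000 nM. Compound 3 gives 350 nM in this assay. The change between them is thiophen-3-yl in place of 1-benzofuran-2-yl on an aromatic carbon, and it made an at least 57-fold lower number from compound 1 to compound 3 (1.75 log units; beyond the scatter); the size rests on (the limit of > 20000 nM in this assay, at which 2 of the 3 values shown sit). For compound 2 the result is likewise a limit, > 20000 nM. The difference between the core of compound 2 and the core of compound 1 is not broken down here.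

Compound 4 `Cc1nc(N)c2c(-c3ccsc3)cn([C@@H]3O[C@H](CO)[C@@H](O)[C@H]3O)c2n1` carries the same kind of change on the core of compound 2: thiophen-3-yl in place of 1-benzofuran-2-yl on an aromatic carbon. Among the measured compounds shown here, the author expects a step of similar size, an at least 66-fold lower number from compound 2 to compound 4 (1.82 log units; beyond the scatter), because the only measured instance of this change, an at least 57-fold lower number from compound 1 to compound 3 (1.75 log units; beyond the scatter), was large and because compound 2 sits at the limit of > 20000 nM in this assay, at which 2 of the 3 values shown sit, so the true starting point is unknown and only a lower bound on the size can be drawn from it. On that basis compound 4 is estimated at 300 nM in this assay, with a range from 40 nM to 4000 nM.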

Compound 4, half-maximal inhibitory concentration: > 20000 nM
Compound 4: a limit, no number; the forecaster's own chance of this, stated with the estimate: 12%; middle value at least 66-fold (1.82 log units) away from the limit.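

In this assay compound 4 gives > 20000 nM, which is a limit and not a number. Compound 2 also stands at a limit, so the step between compound 2 and compound 4 cannot be read: the limit of > 20000 nM in this assay, at which 3 of the 4 values shown sit. The compounds shown leave open whether thiophen-3-yl in place of 1-benzofuran-2-yl changes anything on the core of compound 2.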